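The source may hold more compounds than are shown below. What is called first, only, known or untested is meant among the compounds shown, and "the series" means these compounds.

In an ADME assay on MT2 cells (Homo sapiens) for cytotoxicity, read by XTT assay, with a stated time of 4 days (on this read-out lower numbers stand for higher toxicity in this test and higher numbers for lower toxicity in this test), three compounds have been measured. Compound 1, with the structure `Cc1ccc(-c2c3c(nc(C)c2C(OC(C)(C)C)C(=O)O)CCN(S(C)(=O)=O)C3)cc1`, gives > 40000 nM, which is a limit of the test rather than a number. Compound 3, with the structure `Cc1ccc(-c2c3c(nc(C)c2[C@H](OC(C)(C)C)C(=O)O)CCN(C(=O)OCc2ccccc2)C3)cc1`, gives > 40000 nM, again a limit. Compound 2, with the structure `Cc1nc2c(c(-c3cc(F)c4c(c3C)CCCO4)c1[C@H](OC(C)(C)C)C(=O)O)CN(CCCc1cccc(F)c1)CC2`, gives > 40000 nM, also a limit. So compound 2 stands where all three measured compounds stand: at the limit of > 40000 nM in this assay, at which 3 of the 3 values shown sit, and no number separates it from compound 1 or compound 3.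

Compound 4 has the structure `Cc1nc2c(c(-c3cc(F)c4c(c3C)CCCO4)c1[C@H](OC(C)(C)C)C(=O)O)CN(CCCc1ccc(F)cc1)CC2`. It is compound 2 with one change: 4-fluorophenyl in place of 3-fluorophenyl on a saturated chain carbon, three bonds along the chain from an amine nitrogen in a ring. The two compounds have the same atoms, joined differently.

Going by the values given here, no pair of measured compounds differs in a single place, so no measured step can be pointed to. Since compound 2 sits at the limit, the step from compound 2 to compound 4 in this assay is expected to be none beyond the scatter, with compound 4 expected to remain at the limit as well; the expected step is a step that the limit leaves unreadable from compound 2 to compound 4. Compound 4 is therefore estimated to give 60000 nM in this assay, with an expected range from 30000 nM to 150000 nM.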

Compound 4, half-maximal cytotoxic concentration: > 40000 nM
Compound 4: no number, only a limit (the forecaster's own chance of this, stated with the estimate: 85%); the middle value is on the limit's open side.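

In this assay compound 4 gives > 40000 nM, which is a limit of the test and not a number. Going by these compounds alone, compound 2 rests on a limit too, so no step between compound 2 and compound 4 can be read. Left open is the concentration at which any compound shown harms these cells, and whether 3-fluorophenyl and 4-fluorophenyl differ there.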